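Cytotoxicity notes on the aryl swap series

This account rests on a few compounds, and the source may have more. Where it says the series, first, only, none or still open, it means among the compounds named here.

Compound 1 `C[C@]1(CN2CCc3nc(C4CC4)ccc3C2)Cn2cc([N+](=O)[O-])nc2O1` is recorded in an ADME assay on Vero cells (Chlorocebus sabaeus) for cytotoxicity, read by MTT assay, with a stated time of 72 h (on this read-out higher numbers stand for lower toxicity in this test and lower numbers for higher toxicity in this test), as "not determined" (no result reported). Compound 2 `C[C@]1(CN2CCc3nc(-c4ccc(C(F)(F)F)cc4)ccc3C2)Cn2cc([N+](=O)[O-])nc2O1` reaches only a limit in this assay, > 32 ug/mL. Compound 3 `C[C@]1(CN2CCc3nc(-c4ccc(F)cc4F)ccc3C2)Cn2cc([N+](=O)[O-])nc2O1` gives 12.5 ug/mL in this assay. That is the only single number shown; beside it stand one limit and one entry without a number. Going by the values given here, the step of an at least 2.5-fold lower number from compound 2 to compound 3 (0.40 log units; beyond the scatter) is the one measured change at the aryl group, and it starts from a limit, see (the limit of > 32 ug/mL in this assay, at which 1 of the 3 values shown sits). Compound 4 `C[C@]1(CN2CCc3nc(-c4cc(F)ccc4Cl)ccc3C2)Cn2cc([N+](=O)[O-])nc2O1` differs from compound 3 by 2-chloro-5-fluorophenyl in place of 2,4-difluorophenyl on an aromatic carbon. Among the compounds with values here, only that aryl step bears on this change, and its true size is open, so no step beyond the scatter is expected, a 1.0-fold lower number from compound 3 to compound 4 (0.02 log units; within the scatter). Compound 4 is therefore estimated at 12 ug/mL, with a range of 5 ug/mL to 32 ug/mL.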

Compound 4, half-maximal cytotoxic concentration: > 32 ug/mL
Compound 4 was reported as a limit; the forecaster's own chance of this, stated with the estimate: 20%; middle value at least 2.6-fold (0.42 log units) away from the limit.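

Replacing 2,4-difluorophenyl with 2-chloro-5-fluorophenyl gives an at least 2.5-fold higher number from compound 3 to compound 4 (0.40 log units; beyond the scatter) in this assay, so a change confined to the halogens on this aryl group can move the read-out beyond the scatter. Going by these compounds alone, compound 3 is now the only aryl compound with a single number, and the others sit at a limit: the limit of > 32 ug/mL in this assay, at which 2 of the 4 values shown sit. The step between compound 2 and compound 4 cannot be read, as both values are limits.

Still open, as far as these compounds go, is whether the chlorine or the changed fluorine position carries the step. From the compounds shown here alone, how a phenyl group bearing a methoxy group or an amine would read in this assay also remains open.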